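Notes on Two Inactive Amides and a Phenethyl Analogue

This account rests on a few compounds, and the source may have more. Where it says the series, first, only, none or still open, it means among the compounds named here.

Compound 1 `CCCn1c(NC(=O)c2cc(C)nn2CC)nc2cc(C(N)=O)ccc21` in an assay for activation of interferon regulatory factor 3 (Homo sapiens), read by a luciferase reporter, with a stated time of 20 h (on this read-out lower numbers stand for an effect already at smaller amounts and higher numbers for an effect only at larger amounts of compound), gives only a limit, > 100000 nM.
Compound 2 `CCCn1c(NC(=O)c2cccnn2)nc2cc(C(N)=O)cc(OC)c21` also gives only a limit in this assay, > 100000 nM.

Compound 2 thus stands at the limit, where every value shown sits (the limit of > 100000 nM in this assay, at which 2 of the 2 values shown sit). Compound 3 `CCCn1c(NC(=O)CCc2ccccc2)nc2cc(C(N)=O)cc(OC)c21` differs from compound 2 by phenethyl in place of pyridazin-3-yl on a carbonyl carbon. Among the measured compounds shown here, no measured pair in the set follows this kind of change, so no direction can be read from the data. The step from compound 2 to compound 3 is expected to be a number no higher from compound 2 to compound 3 (the limit leaves the size open), none beyond the usual scatter. Compound 3 is therefore estimated at 100000 nM, within 30000 nM to 300000 nM, most probably again reported only as a limit.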

Compound 3, half-maximal effective concentration: > 100000 nM
Compound 3 ended at the assay's limit; the forecaster's own chance of this, stated with the estimate: 80%; the middle value lies on the limit itself.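

No step can be read from compound 2 to compound 3, since both values are limits: the limit of > 100000 nM in this assay, at which 3 of the 3 values shown sit.

The compounds shown leave open whether any group on the carbonyl carbon gives a value short of the limit.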